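Thiadiazolyl amine in place of the hydroxypropyl pyrazolyl amine

The source may hold more compounds than are shown below. What is called first, only, known or untested is meant among the compounds shown, and "the series" means these compounds.

The series shares one core and varies the amide side and the amine side. In a functional assay on NCI-H3122 cells (Homo sapiens) for antiproliferative activity, read by MTT assay, with a stated time of 48 h (on this read-out higher numbers stand for weaker inhibition and lower numbers for stronger inhibition), compound 1 `COc1cccc(CNC(=O)c2cccc(C(C)Oc3cccnc3Nc3cnn(C)c3)c2)c1` gives 49400 nM and compound 2 `CC(Oc1cccnc1Nc1cnn(C)c1)c1cccc(C(=O)NCc2ccc(Cl)c(C(F)(F)F)c2)c1` gives 50700 nM; the step of a 1.0-fold higher number from compound 1 to compound 2 (0.01 log units; within the scatter) on the amide side sits within the scatter. Compound 3 `Cc1ccc(CNC(=O)c2cccc(C(C)Oc3cccnc3Nc3cnn(CC(C)(C)O)c3)c2)cc1` gives 9100 nM in this assay, the lowest of the three numbers, beyond the scatter from both compound 1 and compound 2.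

Compound 4 `Cc1ccc(CNC(=O)c2cccc(C(C)Oc3cccnc3Nc3nncs3)c2)cc1` is the next step, differing from compound 3 by 1,3,4-thiadiazol-2-yl in place of 1-(2-hydroxy-2-methylpropyl)-1H-pyrazol-4-yl on a nitrogen on an aromatic ring. Among the measured compounds shown here, no measured step touches this position; the only measured step concerns the amide side and is within the scatter, so it gives no guide to the direction here. For the measured compounds named here, the hydroxypropyl pyrazolyl group is present only in compound 3, the single compound with a number beyond the scatter from the rest, so the change is not backed by any pair.

Compound 4 is therefore expected to lie somewhere between compound 3 and the other two, with a 1.6-fold higher number from compound 3 to compound 4 (0.22 log units; within the scatter) as the estimated step and wide uncertainty. For compound 4 the estimate in this assay is 15000 nM, with a range from 4000 nM to 60000 nM.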

Compound 4, half-maximal inhibitory concentration: 20800 nM
Estimate against measurement, compound 4: 1.4-fold (0.14 log units) below, within the range that was stated.
By their numbers in this assay, from the lowest: compound 3; then compound 4; then compounds 1 and 2 (each within the scatter of the next).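

In this assay the amine side now has a measured step of its own: a 2.3-fold higher number from compound 3 to compound 4 (0.36 log units; beyond the scatter) on replacing 1-(2-hydroxy-2-methylpropyl)-1H-pyrazol-4-yl with 1,3,4-thiadiazol-2-yl, a modest change but beyond the scatter. Among the compounds shown here, the only earlier step, a 1.0-fold higher number from compound 1 to compound 2 (0.01 log units; within the scatter) on the amide side, stayed within the scatter, so this is the first single change to move the number, and it moves it towards weaker inhibition. No measured data offer an explanation for this step.

The change swaps the ring and removes the 2-hydroxy-2-methylpropyl chain together, so the contribution of each remains unresolved. Also open, going by these compounds, is how the number responds to a 1,3,4-thiadiazol-2-yl ring carrying that chain, or to a pyrazol-4-yl ring carrying a longer chain ending in an amine or a carboxylic acid.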